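Chloro to methyl: one step measured, one to come

A few compounds are considered here, and "the series" means these few. Any claim that something is new, unique, unknown or untested is made for them only; others in the source may bear on it.

Measured so far in an assay for inhibition of Dihydrofolate reductase (Homo sapiens); a higher number here means a more potent compound, by a factor of ten per unit of this negative logarithm, a lower number a less potent compound:
compound 1 `Nc1nc(N)c2cc(Cl)ccc2n1` gives 5.4
compound 2 `Nc1nc(N)c2c(Cl)c(NC(=O)COc3ccc4ccccc4c3)ccc2n1` gives 7.85
compound 3 `Cc1ccc2nc(N)nc(N)c2c1` gives 5.66

Compound 1 and compound 3 differ by methyl in place of chloro on an aromatic carbon; the step is a number 0.26 log units higher from compound 1 to compound 3 (within the scatter). Compound 2 carries a much larger side chain, and the difference between its core and the core of compound 1 is not broken down here; in this assay compound 2 stands highest of the three, beyond the scatter from both others.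

Compound 4 `Cc1c(NC(=O)COc2ccc3ccccc3c2)ccc2nc(N)nc(N)c12` is not yet measured. It differs from compound 2 by methyl in place of chloro on an aromatic carbon. This is the same kind of change as from compound 1 to compound 3, not the same one: here the place is ortho to a fused ring, ortho to a large group and meta to a fused ring, whereas in the measured pair it is meta and para to a fused ring. Set beside a number 0.26 log units higher from compound 1 to compound 3 (within the scatter), the step from compound 2 to compound 4 is expected to be a number 0.15 log units higher from compound 2 to compound 4 (within the scatter), resting only on that single measured pair. Compound 4 is therefore estimated at 8, between 7.4 and 8.6.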

Compound 4, logarithm of the reciprocal of the active concentration, log(1/C): 7.82
Compound 4: the middle estimate sits 0.18 log units above what was measured; low and high end bracket the measured number.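

Methyl in place of chloro on an aromatic carbon now has two readings in this assay, and the new one, a number 0.03 log units lower from compound 2 to compound 4 (within the scatter), stands with the earlier a number 0.26 log units higher from compound 1 to compound 3 (within the scatter) as a second step without a clear shift. The two readings agree even though the place differs and only compound 2 and compound 4 carry the large side chain: the same change on two cores in this assay, a number 0.26 log units higher (within the scatter) from compound 1 to compound 3 and a number 0.03 log units lower (within the scatter) from compound 2 to compound 4, 0.29 log units apart, within the scatter of two such steps

This supports carrying the change between these two cores in this assay, with values on the second core staying level within the scatter. Among the compounds shown here, it rests on only two pairs and does not show that the same would hold on any other core or at any other place on the ring.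

The compounds shown leave open whether other groups at this place, such as fluoro, an amine, a methoxy or a longer chain like ethyl, would read alike on both cores. They also leave open how far the large side chain alone accounts for the distance between the two cores, as no pair here isolates it.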